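Trading a chloro for a cyano on compound 1

The source may report more compounds than this note shows. Statements on the series, on what has been measured and on what is new or still open speak of the compounds shown alone.

Among the measured compounds shown here, in an ADME assay on the whole organism (Rattus norvegicus, strain Sprague-Dawley) for pharmacokinetics, read by LC-MS, at a dose of 2 mg/kg by the oral route (a higher number here means that a larger share of the oral dose reaches the circulation, a lower number that a smaller share of the oral dose reaches the circulation), compound 1 `N#Cc1ccc(S(=O)(=O)[C@H]2CN(S(=O)(=O)c3ccc(Cl)cc3Cl)C[C@@]2(O)CO)cc1` gives 100%, the highest of the two numbers so far, and compound 2 `N#Cc1ccc(S(=O)(=O)[C@H]2CN(S(=O)(=O)c3ccc(Cl)cc3Cl)C[C@@]2(O)CO)cc1F` gives 51%. For the measured compounds named here, the only measured step, a number 49 percentage points lower from compound 1 to compound 2 (beyond the scatter), is large and beyond the scatter; its change is fluoro in place of hydrogen on an aromatic carbon. Compound 3 `N#Cc1ccc(S(=O)(=O)[C@H]2CN(S(=O)(=O)c3ccc(C#N)cc3Cl)C[C@@]2(O)CO)cc1` has not yet been measured in this assay. It departs from compound 1 at a different place: cyano in place of chloro on an aromatic carbon. This is cyano in place of chloro on an aromatic carbon, para to a large group, turning 2,4-dichlorophenyl into 2-chloro-4-cyanophenyl. Going by the values given here, no measured step covers this exchange, so the step to compound 2 bears on it only indirectly, showing that a single exchange on an aromatic carbon can move the number far. Compound 1, at 100%, leaves little room upward, so any clear move is expected to be downward. The estimated step, a number 35 percentage points lower from compound 1 to compound 3 (beyond the scatter), is expected to be sizeable but uncertain. Compound 3 is expected at 65%, with an estimated range from 35% to 100%.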

Compound 3, oral bioavailability: 15%
Compound 3: the middle estimate sits 50 percentage points above what was measured, and the stated range ends above it.
By their numbers in this assay, from the lowest: compound 3; then compound 2; then compound 1.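

In this assay, trading chloro for cyano on an aromatic carbon, which turns 2,4-dichlorophenyl into 2-chloro-4-cyanophenyl, gives a number 85 percentage points lower from compound 1 to compound 3 (beyond the scatter) and counts as a large step. The earlier pair showed only that fluoro in place of hydrogen at a different place could move the number, whereas this result shows that the position para to a large group and meta to a chloro group is sensitive as well, with compound 1 losing much of its high this assay reading when this one group is exchanged. Nothing measured here accounts for the size of this drop, which therefore stands as an observation without an explanation.

The compounds shown hold only chloro and cyano at this position, so it remains open whether a methyl group, a methoxy group or an amine there would keep the number close to that of compound 1 at 100% in this series. On these data alone, it also remains open whether the same exchange would have a step of similar size on a compound that carries the fluoro of compound 2.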